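The source may hold more compounds than are shown below. What is called first, only, known or untested is meant among the compounds shown, and "the series" means these compounds.

Measured so far:
- compound 1 `CC(C)C(Cc1ncc[nH]1)c1ccc(-c2ccc3cccc(F)c3c2)[nH]c1=O`, < 0.0667 h
- compound 2 `CC(C)[C@H](C[C@H]1CCNC1=O)c1ccc(-c2ccc3cccc(F)c3c2)[nH]c1=O`, 0.227 h
- compound 3 `CC(C)[C@@H](C[C@H]1CCNC1=O)c1ccc(-c2ccc3cccc(F)c3c2)[nH]c1=O`, 0.507 h

In an ADME assay on microsomes from liver (Rattus norvegicus) for metabolic stability (on this read-out higher numbers stand for a longer-lived compound and lower numbers for a shorter-lived compound), compound 1 gives only < 0.0667 h, which is a limit of the assay and not a number. Compound 2 gives 0.227 h and compound 3 gives 0.507 h; the step of a 2.2-fold higher number from compound 2 to compound 3 (0.35 log units; beyond the scatter) arises because of the fact that compounds 2 and 3 differ only in the configuration as drawn, so even configuration alone at the chain carbon moves the number beyond the scatter.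

Compound 4 `CC(C)C(Cc1noc(=O)[nH]1)c1ccc(-c2ccc3cccc(F)c3c2)[nH]c1=O` follows from compound 1 by a group of 6 heavy atoms (2 carbon, 2 nitrogen, 2 oxygen; one five-membered aromatic ring with 3 hetero atoms) in place of a group of 5 heavy atoms (3 carbon, 2 nitrogen; one five-membered aromatic ring with 2 hetero atoms), on a saturated chain carbon, two bonds along the chain from an aromatic carbon. Within the data shown here, no measured step touches this group: the only measured step swaps the configuration of a different part of the shared core, and compound 1 itself stands at the limit, so the starting point is known only as a ceiling. The step from compound 2 to compound 3 sets the scale of what a small change can do here. A modest rise in this assay is expected, of about an at least 1.7-fold higher number from compound 1 to compound 4 (0.25 log units; that floor lies within the scatter), with wide uncertainty. Compound 4 is therefore estimated at 0.12 h, within a range from 0.05 h to 0.35 h.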

Compound 4, half-life: > 3 h
Compound 4: a limit, no number (the forecaster's own chance of this, stated with the estimate: 35%); middle value at least 25-fold (1.39 log units) from the limit.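

Putting the new ring with three hetero atoms in place of 1H-imidazol-2-yl, on a saturated chain carbon, two bonds along the chain from an aromatic carbon, gives an at least 44-fold higher number from compound 1 to compound 4 (1.65 log units; beyond the scatter) in this assay. In this assay compound 4 gives > 3 h, which is a limit of the assay and not a number. Among these compounds, the only step known earlier, a 2.2-fold higher number from compound 2 to compound 3 (0.35 log units; beyond the scatter), came from configuration alone, whereas this result shows that changing the group itself at this position can move the half-life much further, taking the series from one end of the measured range to the other.

Still open, on these data alone, is whether a different group at the same place, such as a carboxylic acid or a primary amide, would behave more like compound 1 or more like compound 4, and how far configuration at the chain carbon, which is not drawn for compound 4, would matter with this new ring in place. Nothing among the compounds shown explains why this exchange has so large an effect on the half-life.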